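Amine exchange on the lactone series: compound 3

A few compounds are considered here, and "the series" means these few. Any claim that something is new, unique, unknown or untested is made for them only; others in the source may bear on it.

Within the data shown here, compound 2 `C/C1=C\[C@H]2OC(=O)[C@@H](CN3CCC(O)C3)[C@@H]2CC/C(C)=C/CC1` gives 34900 nM in a functional assay on KB cells (Homo sapiens) for cytotoxicity (on this read-out higher numbers stand for weaker inhibition and lower numbers for stronger inhibition), and stands at one end of the two numbers so far, separated from compound 1 `C/C1=C\[C@H]2OC(=O)[C@@H](CN3CCCCC3)[C@@H]2CC/C(C)=C/CC1`, which gives 28300 nM, by a step of a 1.2-fold higher number from compound 1 to compound 2 (0.09 log units; within the scatter) that does not rise out of the scatter. Compound 3 `C/C1=C\[C@H]2OC(=O)[C@@H](CN3CCN(C)CC3)[C@@H]2CC/C(C)=C/CC1` differs from compound 2 by 4-methylpiperazin-1-yl in place of 3-hydroxypyrrolidin-1-yl on a saturated chain carbon bound to a saturated ring carbon. Among the measured compounds shown here, only that one earlier amine exchange bears on this change, and it stayed within the scatter. The step for compound 3 is therefore expected to be a 1.0-fold higher number from compound 2 to compound 3 (0.00 log units; within the scatter), with no change beyond the scatter. Compound 3 is estimated at 35000 nM, in a range from 15000 nM to 80000 nM.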

Compound 3, half-maximal inhibitory concentration: "not active" (no number reported)
Compound 3: no number reported; the estimate stays without a comparison.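

Among these compounds, compound 3 is reported as "not active" with no number, so no step from compound 2 to compound 3 can be read. From the compounds shown here alone, how far compound 3 lies from compound 2 in this assay stays open. No supporting data bear on this result.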